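The source may report more compounds than this note shows. Statements on the series, on what has been measured and on what is new or still open speak of the compounds shown alone.

Compound 1 `O=C(NNc1ccnc2cc(Cl)ccc12)c1ccccc1/N=C/c1cccc(Cl)c1Cl`: 6.1
Compound 2 `O=C(NNc1ccnc2cc(Cl)ccc12)c1ccccc1/N=C/c1ccc(Cl)c(Cl)c1`: 6.22
Compound 3 `Cc1ccc(/C=N/c2ccccc2C(=O)NNc2ccnc3cc(Cl)ccc23)cc1`: not yet measured

In a physicochemical assay for lipophilicity, measured as octanol-water partition (a higher number here means a more lipophilic compound, a lower number a more polar compound), compound 2 gives 6.22, level with compound 1 at 6.1. Among the compounds with values here, the only measured step is a number 0.12 log units higher from compound 1 to compound 2 (within the scatter).

Compound 3 carries 4-methylphenyl in place of 3,4-dichlorophenyl on a carbon with a double bond to nitrogen. The measured step bears on this only weakly, since it exchanges one dichlorophenyl for another. Here the chlorine leaves altogether, and no measured pair shows such a change. A lower number in this assay is still expected, by more than the scatter, though its size is a judgement and the range is kept wide. The expected step is a number 0.62 log units lower from compound 2 to compound 3 (beyond the scatter). The value expected for compound 3 is 5.6, within an estimated range from 5.2 to 6.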

Compound 3, partition coefficient: 5.31
Compound 3: the middle estimate sits 0.29 log units above what was measured, and the stated range covers the measured number.
By their numbers in this assay, from the lowest: compound 3; then compounds 1 and 2 (each within the scatter of the next).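

In this assay, 4-methylphenyl in place of 3,4-dichlorophenyl gives a number 0.91 log units lower from compound 2 to compound 3 (beyond the scatter) and in place of 2,3-dichlorophenyl gives a number 0.79 log units lower from compound 1 to compound 3 (beyond the scatter) on the same carbon with a double bond to nitrogen. Moving the chlorines gave only a number 0.12 log units higher from compound 1 to compound 2 (within the scatter), so this position now shows a change beyond the scatter once both chlorines leave and methyl enters, with either dichlorophenyl as the starting point. Nothing available accounts for the size of these steps.

Within the data shown here, the single exchange removes chlorine and adds methyl together, so the share of each stays unresolved. Open too, from the compounds shown here alone, is where a plain phenyl, a monochlorophenyl, or a phenyl carrying an amine or a carboxylic acid would fall on this scale.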